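A Second Methoxy Added to Compound 2

This account rests on a few compounds, and the source may have more. Where it says the series, first, only, none or still open, it means among the compounds named here.

In a functional assay on HCT-116 cells (Homo sapiens) for cytotoxicity (on this read-out lower numbers stand for an effect already at smaller amounts and higher numbers for an effect only at larger amounts of compound), compound 1 `COc1cccc(S(=O)(=O)Nc2ccc(C(=O)CSC(C)=O)cc2)c1` gives 2600 nM, while compound 2 `COc1ccc(S(=O)(=O)Nc2ccc(C(=O)CSC(C)=O)cc2)cc1` gives 500 nM, the lower of the two numbers. Compound 3 `COc1ccc(S(=O)(=O)Nc2ccc(C(=O)CSC(C)=O)cc2)cc1OC` keeps the methoxy of compound 2 and gains another: methoxy in place of hydrogen on an aromatic carbon. This is methoxy in place of hydrogen on an aromatic carbon, ortho to a methoxy group and meta to a large group.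

For the measured compounds named here, only one measured step bears on this change: a 5.2-fold lower number from compound 1 to compound 2 (0.72 log units; beyond the scatter), with 4-methoxyphenyl in place of 3-methoxyphenyl on a sulfonyl sulfur. Compound 3 carries the methoxy groups of both earlier compounds, so its number may move towards that of compound 1 at 2600 nM. One step is thin evidence, so only a modest rise is expected. The expected change in this assay is a 1.8-fold higher number from compound 2 to compound 3 (0.26 log units; within the scatter). For compound 3, the estimated value is 900 nM, within an expected range of 300 nM to 2700 nM.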

Compound 3, half-maximal effective concentration: 3200 nM
The estimate for compound 3 lay 3.6-fold (0.55 log units) below the measured number, and the stated range ends below it.
By their numbers in this assay, from the lowest: compound 2; then compounds 1 and 3 (each within the scatter of the next).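

In this assay, methoxy on this aromatic carbon, ortho to a methoxy group, is not tolerated without cost: adding it gives a 6.4-fold higher number from compound 2 to compound 3 (0.81 log units; beyond the scatter), which removes the advantage compound 2 held. On the other methoxy compound, the same addition gives a 1.2-fold higher number from compound 1 to compound 3 (0.09 log units; within the scatter), so compound 1 and compound 3 stand level, and the result of adding a methoxy depends on which methoxy the ring already carries. Among these three compounds, the lowest number belongs only to the ring with the single methoxy of compound 2, and nothing given here explains why.

As far as these compounds go, whether the rise is specific to methoxy remains open, since a fluorine atom or a hydroxyl group on the same carbon could behave differently. From the compounds shown here alone, it is also open whether an ethoxy group in place of either methoxy would shift the number.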